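Sulfonyl step on the compound 3 core, all limits so far

This account rests on a few compounds, and the source may have more. Where it says the series, first, only, none or still open, it means among the compounds named here.

In a functional assay on the whole organism for antagonist activity, with Mus musculus as the target (on this read-out lower numbers stand for an effect already at smaller amounts and higher numbers for an effect only at larger amounts of compound), compound 1 `CSc1n[nH]c(-c2ccc(F)cc2)n1` gives > 200 mg/kg, which is a limit and not a number. Compound 2 `CSc1nnc(-c2ccc(F)cc2)n1C` gives > 200 mg/kg, also a limit. Compound 3 `Cn1c(-c2cccs2)nnc1[S+](C)[O-]` gives > 200 mg/kg, again only a limit. The series therefore sits at one ceiling: the limit of > 200 mg/kg in this assay, at which 3 of the 3 values shown sit.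

Compound 4 `Cn1c(-c2cccs2)nnc1S(C)(=O)=O` places methylsulfonyl on an aromatic carbon of the core of compound 3 (a group of 4 heavy atoms (1 carbon, 2 oxygen, 1 sulfur; no ring) in place of a group of 3 heavy atoms (1 carbon, 1 oxygen, 1 sulfur; no ring), on an aromatic carbon). Among the measured compounds shown here, no measured step is available as a guide, so any size in this assay is uncertain. A modest move towards smaller doses is expected, though the read-out may remain a limit. The estimated step is an at least 2.0-fold lower number from compound 3 to compound 4 (0.30 log units; that floor lies within the scatter). For compound 4 the expected value is 100 mg/kg, with an estimated range of 25 mg/kg to 300 mg/kg.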

Compound 4, dose for half-maximal effect: > 200 mg/kg
Compound 4: no number, only a limit; the forecaster's own chance of this, stated with the estimate: 45%; at least 2.0-fold (0.30 log units) between middle value and limit.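

Among the compounds shown here, compound 4 gives > 200 mg/kg as only a limit, and compound 3 is also only a limit, so no step between the two can be read. The compounds shown leave open whether any change on the shared core yields a measurable dose.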